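Hydroxylating the isopropyl of a weak inhibitor

The source may report more compounds than this note shows. Statements on the series, on what has been measured and on what is new or still open speak of the compounds shown alone.

Compound 1 `Cc1c2c(cc(C(C)C)cc1=O)[C@@H](C)CC2`: > 30000 nM
Compound 2 `Cc1c2c(cc(C(C)C)cc1=O)[C@@H](C)C[C@@H]2O`: > 30000 nM
Compound 3 `Cc1c2c(cc(C(C)C)cc1=O)[C@@H](C)C[C@H]2O`: 26000 nM

In a functional assay on BV-2 cells (Mus musculus) for inhibition, read by Griess assay, with a stated time of 24 h (on this read-out lower numbers stand for stronger inhibition and higher numbers for weaker inhibition), compound 1 reaches only a limit of the assay, > 30000 nM. Compound 2 also reaches only a limit, > 30000 nM. Compound 3 gives a number, 26000 nM. Compound 2 thus stands at the weak end of the numbers shown, because of the limit of > 30000 nM in this assay, at which 2 of the 3 values shown sit.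

The new compound 4 `Cc1c2c(cc(C(C)(C)O)cc1=O)[C@@H](C)C[C@@H]2O` differs from compound 2 by hydroxy in place of hydrogen on a saturated chain carbon bound to an aromatic carbon and two saturated chain carbons. Among the measured compounds shown here, none of the measured steps makes this change: a step that the two limits leave unreadable from compound 1 to compound 2, an at least 1.1-fold lower number from compound 1 to compound 3 (0.06 log units; that floor lies within the scatter) and an at least 1.1-fold lower number from compound 2 to compound 3 (0.06 log units; that floor lies within the scatter) all concern the saturated ring carbon, and their sizes stay within the scatter or cannot be read. No step beyond the scatter is therefore expected in this assay, and compound 4 is expected to reach only a limit again.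

Compound 4 is estimated at 40000 nM, between 15000 nM and 150000 nM, a step that the limit leaves unreadable from compound 2 to compound 4.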

Compound 4, half-maximal inhibitory concentration: > 30000 nM
Compound 4: no number, only a limit; the forecaster's own chance of this, stated with the estimate: 75%; the middle value is on the limit's open side.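

Among the compounds shown here, compound 2 and compound 4 both give only a limit of this assay, so no step between them can be read. The compounds shown leave open whether changing isopropyl to 1-hydroxy-1-methylethyl alters inhibition at all.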